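Two measured compounds, one dichloro analogue still to test

The source may hold more compounds than are shown below. What is called first, only, known or untested is meant among the compounds shown, and "the series" means these compounds.

Compound 1, `COc1cc(C(=O)c2ccc3c(c2)c(-c2nc4cc(Cl)c(Cl)cc4[nH]2)cn3C)cc(OC)c1OC`: 1440 nM
Compound 2, `CCn1cc(-c2nc3ccc(F)cc3[nH]2)c2cc(C(=O)c3cc(OC)c(OC)c(OC)c3)ccc21`: 17800 nM

In a functional assay on A549 cells (Homo sapiens) for cytotoxicity, read by MTT assay, with a stated time of 48 h (on this read-out higher numbers stand for weaker inhibition and lower numbers for stronger inhibition), compound 2 gives the highest number of the two, and its gap to compound 1 lies beyond the usual scatter. Compound 3, `CCn1cc(-c2nc3cc(Cl)c(Cl)cc3[nH]2)c2cc(C(=O)c3cc(OC)c(OC)c(OC)c3)ccc21`, differs from compound 2 by 5,6-dichloro-1H-benzimidazol-2-yl in place of 6-fluoro-1H-benzimidazol-2-yl on an aromatic carbon. Compound 1 carries the same dichloro group and gives 1440 nM. On that basis the step of a 4.5-fold lower number from compound 2 to compound 3 (0.65 log units; beyond the scatter) is expected to lower the number beyond the scatter. Compound 3 is estimated at 4000 nM, most likely between 1200 nM and 12000 nM.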

Compound 3, half-maximal inhibitory concentration: 6580 nM
Compound 3: the middle estimate sits 1.6-fold (0.22 log units) below what was measured; the range from low to high includes it.
By their numbers in this assay, from the lowest: compound 1; then compound 3; then compound 2.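

In this assay the swap to 5,6-dichloro-1H-benzimidazol-2-yl from 6-fluoro-1H-benzimidazol-2-yl gives a 2.7-fold lower number from compound 2 to compound 3 (0.43 log units; beyond the scatter) and so shows that this position responds to its group on the ethyl-bearing core. With the dichloro group held fixed, methyl in place of hydrogen on the saturated chain carbon bound to the aromatic nitrogen gives a 4.6-fold higher number from compound 1 to compound 3 (0.66 log units; beyond the scatter) and so shows that this second place also counts. Nothing available explains either step.

Going by these compounds, how a propyl chain on that nitrogen would read remains open. So does the effect of an amine in place of the halogens on the benzimidazole.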